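The source may hold more compounds than are shown below. What is called first, only, known or untested is meant among the compounds shown, and "the series" means these compounds.

Measured so far:

Compound 1, `COc1ccc(N2C(=O)COc3ccc(-c4ccc(O)cc4)cc32)cc1`: in a functional assay on HCT-116 cells (Homo sapiens) for antiproliferative activity, read by MTT assay, with a stated time of 72 h (on this read-out higher numbers stand for weaker inhibition and lower numbers for stronger inhibition), compound 1 gives 26100 nM.
Compound 2, `O=C1COc2ccc(-c3cnc(Cl)c(NS(=O)(=O)c4ccc(F)cc4)c3)cc2N1c1ccc(Cl)cc1`: compound 2 gives 27900 nM.
Compound 3, `COc1ncc(-c2ccc3c(c2)N(c2ccc(Cl)cc2)C(=O)CO3)cc1NS(=O)(=O)c1ccc(F)cc1`: compound 3 gives 19200 nM.

Compound 3 stands within the scatter of both other compounds: its gap to compound 1 is within the scatter, and the step of a 1.5-fold lower number from compound 2 to compound 3 (0.16 log units; within the scatter) is likewise within the scatter, so the three numbers cannot be told apart on this read-out.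

Compound 4, `COc1cccc(N2C(=O)COc3ccc(-c4cnc(OC)c(NS(=O)(=O)c5ccc(F)cc5)c4)cc32)c1`, differs from compound 3 in one place: 3-methoxyphenyl in place of 4-chlorophenyl on an amide-type nitrogen in a ring. Within the data shown here, the only single-place step in the set, a 1.5-fold lower number from compound 2 to compound 3 (0.16 log units; within the scatter), concerns the substituent on the aromatic ring bearing the sulfonamide, not the group on the amide-type nitrogen in a ring, and it lay within the scatter. Compound 1 differs from compound 3 at more than one place, so its value gives no isolated reading of the present change. Among the measured compounds shown here, no measured step bears directly on it. The expectation for compound 4 in this assay is therefore a step no larger than the scatter, a 1.1-fold higher number from compound 3 to compound 4 (0.06 log units; within the scatter). Compound 4 is estimated at 22000 nM, in the range 9000 nM to 55000 nM.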

Compound 4, half-maximal inhibitory concentration: > 40000 nM
Compound 4: a limit, no number (the forecaster's own chance of this, stated with the estimate: 10%); middle value at least 1.8-fold (0.25 log units) from the limit.
By their numbers in this assay, from the lowest: compounds 3, 1 and 2 (each within the scatter of the next). At a limit, above all of these: compound 4.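

Among these compounds, at the amide-type nitrogen in a ring, the only single-place reading gives, in this assay, an at least 2.0-fold higher number from compound 3 to compound 4 (0.31 log units; beyond the scatter), with 3-methoxyphenyl in place of 4-chlorophenyl. Among the compounds shown here, the one earlier step, a 1.5-fold lower number from compound 2 to compound 3 (0.16 log units; within the scatter), concerned methoxy in place of chloro on an aromatic carbon elsewhere in the molecule, so this is the first change to go beyond the scatter. Compound 4 reads > 40000 nM, which is a limit of the assay and not a number, so the step has a lower bound but no measured size: the limit of > 40000 nM in this assay, at which 1 of the 4 values shown sits.

4-Chlorophenyl and 3-methoxyphenyl differ both in the substituent and in its place on the ring, and the compounds shown do not separate the two. On these data alone, how an unsubstituted phenyl or a pyridyl group on that nitrogen would read remains open.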